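Chain amine variants of the shared core

A few compounds are considered here, and "the series" means these few. Any claim that something is new, unique, unknown or untested is made for them only; others in the source may bear on it.

Compound 2 `CC(C)(N)CN(C(=O)[C@@H]1C[C@H]1c1ccccc1)c1ccc(-c2ccccc2)cc1` holds the only number shown in a functional assay for agonist activity at G protein-coupled receptor 88 (Homo sapiens), read by HTRF and cAMP accumulation; on this read-out lower numbers stand for an effect already at smaller amounts and higher numbers for an effect only at larger amounts of compound: compound 2 gives 1.4 nM. The other member, compound 1 `CC(C)CCCN(C(=O)[C@@H]1C[C@H]1c1ccccc1)c1ccc(-c2ccccc2)cc1`, sits in this assay at > 100 nM, a limit rather than a number. For the measured compounds named here, the one measured step reads an at least 71-fold lower number from compound 1 to compound 2 (1.85 log units; beyond the scatter). Compound 3 `CCC(CC)C(N)CCN(C(=O)[C@@H]1C[C@H]1c1ccccc1)c1ccc(-c2ccccc2)cc1` differs from compound 2 by 2-amino-3-ethylpentyl in place of 1-amino-1-methylethyl on a saturated chain carbon bound to an amide-type nitrogen. Going by the values given here, only that large step bears on it; the amine of compound 2 is kept while the chain grows, so a moderate rise is expected, a 5.7-fold higher number from compound 2 to compound 3 (0.76 log units; beyond the scatter). Compound 3 is estimated at 8 nM, between 1.5 nM and 60 nM.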

Compound 3, half-maximal effective concentration: 2 nM
Beside the measured number, compound 3's estimate is 4.0-fold (0.60 log units) above it; low and high end bracket the measured number.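

On a saturated chain carbon bound to an amide-type nitrogen, the larger 2-amino-3-ethylpentyl holds up as well as 1-amino-1-methylethyl: in this assay the change reads a 1.4-fold higher number from compound 2 to compound 3 (0.15 log units; within the scatter) and leaves the two values indistinguishable. Both amine chains sit far from the isopentyl of compound 1, and the new pair reads an at least 50-fold lower number from compound 1 to compound 3 (1.69 log units; beyond the scatter) in this assay for this comparison. Compound 1 gives a limit rather than a number: the limit of > 100 nM in this assay, at which 1 of the 3 values shown sits.

As far as these compounds go, a hydroxyl or carboxylic acid in place of the amine remains open. So does an amine-free chain as long as 2-amino-3-ethylpentyl, and the shares of amine and chain length stay unseparated.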